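This account rests on a few compounds, and the source may have more. Where it says the series, first, only, none or still open, it means among the compounds named here.

Compound 1 `O[C@@H]1Cc2ccccc2[C@H]1NC1CCN(CCCc2c[nH]c3ccc(-n4cnnc4)cc23)CC1` is one of three compounds tested in an assay on CHO cells for displacement of a labelled ligand from 5-hydroxytryptamine receptor 1B (Homo sapiens); on this read-out lower numbers stand for stronger inhibition and higher numbers for weaker inhibition; compound 1 gives 210 nM. Compound 3 `C[C@@H](NC1CCN(CCCc2c[nH]c3ccc(-n4ccnc4)cc23)CC1)c1ccccc1` gives 110 nM, a value within the usual scatter of that of compound 1, so the two cannot be told apart. Compound 2 `OC[C@H](NC1CCN(CCCc2c[nH]c3ccc(Cn4cncn4)cc23)CC1)c1ccccc1` gives 1300 nM, a weaker result than compound 1 that lies beyond the scatter; compound 1 thus sits second highest of the three numbers. Compound 4 `c1ccc(NCC2CCN(CCCc3c[nH]c4ccc(-n5cnnc5)cc34)CC2)nc1` has not been measured. It differs from compound 1 in one place: ((pyridin-2-yl)amino)methyl in place of (2-hydroxy-2,3-dihydro-1H-inden-1-yl)amino on a saturated ring carbon. For the measured compounds named here, no measured pair shows a change of this kind, so the step is uncertain. Compound 4 is expected to be somewhat weaker, with an estimated step of a 2.4-fold higher number from compound 1 to compound 4 (0.38 log units; beyond the scatter) in this assay. The estimate for compound 4 is 500 nM, within a range from 120 nM to 2500 nM.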

Compound 4, half-maximal inhibitory concentration: 3.3 nM
Beside the measured number, compound 4's estimate is 150-fold (2.18 log units) above it, outside the stated range (below it).
By their numbers in this assay, from the lowest: compound 4; then compounds 3 and 1 (each within the scatter of the next); then compound 2.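

Putting ((pyridin-2-yl)amino)methyl in place of (2-hydroxy-2,3-dihydro-1H-inden-1-yl)amino on this saturated ring carbon gives a 64-fold lower number from compound 1 to compound 4 (1.80 log units; beyond the scatter) in this assay, so this position has a large influence on the read-out. The defined stereocentres of the departing group are not needed for a low number here. No measurement at hand explains the gain.

Going by these compounds, it remains open which part of the entering group matters: the pyridine ring, the amine or the methylene link. A (phenylamino)methyl group or a (pyridin-2-yl)oxymethyl ether at this position would help separate them.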